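The compounds below may be only part of what the source reports. "The series", "measured", "known", "first", "only" and "open" are said of these compounds alone.

Within the data shown here, in a functional assay on MC-38 cells (Mus musculus) for antiproliferative activity, read by colorimetric assay and MTT assay (a higher number here means a weaker inhibitor, a lower number a stronger inhibitor), compound 3 `Nc1ccc(S(=O)(=O)Nc2cccc3cc[nH]c23)cc1` gives 6.1 ug/mL, the highest number of the three measured so far. Compound 4 `Nc1ccc(S(=O)(=O)Nc2cccc3c(Cl)c[nH]c23)cc1` differs from it by chloro in place of hydrogen on an aromatic carbon. Among the measured compounds shown here, no measured step makes this exact change. The only one available, a 2.2-fold lower number from compound 1 to compound 2 (0.33 log units; beyond the scatter), is modest and swaps chloro for cyano at another place. Two compounds that already carry the new chloro group offer a rough guide, although both also differ from compound 3 at a second place: compound 1 `O=S(=O)(Nc1cccc2c(Cl)c[nH]c12)c1ccc(Cl)cc1` gives 0.28 ug/mL and compound 2 `N#Cc1ccc(S(=O)(=O)Nc2cccc3c(Cl)c[nH]c23)cc1` gives 0.13 ug/mL. Part of their gap to compound 3 may belong to that second difference, so a large but incomplete drop is expected in this assay. The expected size is a 12-fold lower number from compound 3 to compound 4 (1.09 log units; beyond the scatter). For compound 4 the estimated value is 0.5 ug/mL, with an expected range of 0.15 ug/mL to 1.6 ug/mL.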

Compound 4, half-maximal inhibitory concentration: 0.23 ug/mL
For compound 4 the middle estimate is 2.2-fold (0.34 log units) above the measured one; the range from low to high includes it.
By their numbers in this assay, from the lowest: compounds 2, 4 and 1 (each within the scatter of the next, the first and the last beyond it); then compound 3.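

In this assay, chloro in place of hydrogen on an aromatic carbon of the five-membered ring, with nothing else altered, gives a large step (a 27-fold lower number from compound 3 to compound 4 (1.42 log units; beyond the scatter)). Among these compounds, this is the first reading of this change alone. With that chloro present, the amino, cyano and chloro versions of the other aromatic substituent cannot be told apart (a 1.8-fold higher number from compound 2 to compound 4 (0.25 log units; within the scatter)) and (a 1.2-fold lower number from compound 1 to compound 4 (0.09 log units; within the scatter)).

Nothing here measures why the chloro step is so large. On these data alone, whether bromo, fluoro or methyl at the same place would match chloro remains open.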